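Dropping the nitro group: where compound 4 might land

This account rests on a few compounds, and the source may have more. Where it says the series, first, only, none or still open, it means among the compounds named here.

Three compounds of this series carry measurements in an ADME assay on BJ cells (Homo sapiens) for antiproliferative activity, with a stated time of 72 h; a lower number here means that less compound is needed, a higher number that more compound is needed for the effect. Compound 1 `COc1ccc(-c2cc(=O)c3c(OC)cc(OC)cc3n2C)cc1` gives 68000 nM. Compound 2 `COC(=O)c1cc(=O)c2c(OC)cc(OC)cc2n1S(=O)(=O)c1ccc(C)cc1` gives 139000 nM. Compound 3 `COc1ccc(-c2cc(=O)c3c(OC)cc(OC)cc3n2S(=O)(=O)c2ccc(C)c([N+](=O)[O-])c2)cc1` reaches only a limit of the assay, > 51700 nM, and its position is therefore known only as the limit of > 51700 nM in this assay, at which 1 of the 3 values shown sits, rather than as a number. Of the three, compound 3 is the one for which the study yields a bound and not a value.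

Compound 4 `COc1ccc(-c2cc(=O)c3c(OC)cc(OC)cc3n2S(=O)(=O)c2ccc(C)cc2)cc1` has not yet been measured. It differs from compound 3 in a single place: hydrogen in place of nitro on an aromatic carbon. Among the measured compounds shown here, no measured pair in the set shares this change, so the step from compound 3 to compound 4 in this assay rests on expectation alone. The author expects no step beyond the usual scatter, an estimated step that the limit leaves unreadable from compound 3 to compound 4. Compound 4 is accordingly estimated at 70000 nM, with a range from 30000 nM to 200000 nM, and with a fair chance that the assay once more reports only a limit.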

Compound 4, half-maximal effective concentration: > 44800 nM
Compound 4: only a limit was reported; the forecaster's own chance of this, stated with the estimate: 45%; the middle value lies beyond the limit too.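

In this assay, among the compounds shown here, compound 4 reaches only a limit of the assay, > 44800 nM, so no step from compound 1, compound 2 or compound 3 to compound 4 can be read. The compounds shown leave open where compound 3 and compound 4 actually lie in this assay, and whether hydrogen in place of nitro changes their position at all.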